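A few compounds are considered here, and "the series" means these few. Any claim that something is new, unique, unknown or untested is made for them only; others in the source may bear on it.

Working notes on the series.

Compound 1 `COC(=O)[C@@]1(C)CC[C@@H]2C3=C1CC[C@@H](C)[C@]3(C)Cc1c2[nH]c2ccccc12` is the parent; in a functional assay on HeLa cells (Homo sapiens) for inhibition, read by sulforhodamine B assay, with a stated time of 48 h (a higher number here means a weaker inhibitor of growth, a lower number a stronger inhibitor of growth), compound 1 gives 3200 nM. Among the three measured compounds compound 1 holds the lowest number, although compound 3 `COC(=O)[C@@]1(C)CC[C@@H]2C3=C1CC[C@@H](C)[C@]3(C)Cc1c2[nH]c2ccc(OC)cc12`, a methoxy analogue, gives 3900 nM and the step of a 1.2-fold higher number from compound 1 to compound 3 (0.09 log units; within the scatter) lies within the scatter, so the two cannot be ordered. Compound 2 `COC(=O)[C@@]1(C)CC[C@@H]2C3=C1CC[C@@H](C)[C@]3(C)Cc1c2[nH]c2ccc(Br)cc12`, a bromo analogue, gives 14000 nM; the step of a 4.4-fold higher number from compound 1 to compound 2 (0.64 log units; beyond the scatter) is beyond the scatter, and a 3.6-fold lower number from compound 2 to compound 3 (0.56 log units; beyond the scatter) places the methoxy compound back near the parent.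

Compound 4 `COC(=O)[C@@]1(C)CC[C@@H]2C3=C1CC[C@@H](C)[C@]3(C)Cc1c2[nH]c2c(Cl)cccc12` is the next case. It differs from compound 1 only as follows: chloro in place of hydrogen on an aromatic carbon. Of the measured steps, only the halogen entry from compound 1 to compound 2 bears on this change, and it was modest, in the direction of a higher number; the chloro of compound 4 enters at a different position on the aromatic ring, so that step is a rough guide only. A rise of similar or smaller size in this assay is expected, with a result inside the scatter also plausible.

Compound 4 is expected to give about 6000 nM in this assay, within a range of 2500 nM to 15000 nM. This expected step, a 1.9-fold higher number from compound 1 to compound 4 (0.27 log units; within the scatter), rests on the halogen step seen as a 4.4-fold higher number from compound 1 to compound 2 (0.64 log units; beyond the scatter).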

Compound 4, concentration for 50% growth inhibition: 12000 nM
Beside the measured number, compound 4's estimate is 2.0-fold (0.30 log units) below it; low and high end bracket the measured number.
By their numbers in this assay, from the lowest: compounds 1 and 3 (each within the scatter of the next); then compounds 4 and 2 (each within the scatter of the next).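

In this assay, chloro in place of hydrogen on this aromatic carbon, ortho to a fused ring and meta to a fused ring, gives a 3.8-fold higher number from compound 1 to compound 4 (0.57 log units; beyond the scatter), so a single added chlorine atom at this position is enough for a change beyond the scatter. Among these compounds, until now the only such halogen step was a 4.4-fold higher number from compound 1 to compound 2 (0.64 log units; beyond the scatter), at another place on the ring; the series now holds two halogen entries that raise the number, at two places, while the methoxy entry of compound 3 goes against any wider rule for added groups, with a 1.2-fold higher number from compound 1 to compound 3 (0.09 log units; within the scatter) lying within the scatter. The data at hand give no measurement that would explain the rise at this position.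

The compounds shown leave open whether the rise follows from chloro in particular or from any group on this carbon, a question that a methoxy, a fluoro or an amine at the same position would address. They also leave open how far the halogen and the place each count, since the two halogens sit at different places and chloro at the place of the bromo of compound 2 would be needed to separate them.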